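A few compounds are considered here, and "the series" means these few. Any claim that something is new, unique, unknown or untested is made for them only; others in the source may bear on it.

Series notes, chalcone–triazole–coumarin conjugates, growth read-out in a functional assay on COLO 205 cells (Homo sapiens) for inhibition, read by sulforhodamine B assay, with a stated time of 48 h, tested at 50 uM; on this read-out higher numbers stand for more inhibition of growth at the one concentration tested and lower numbers for less inhibition of growth.

Measured compounds:
- compound 1, `COc1cc(/C=C/C(=O)/C=C/c2ccccc2)ccc1OCc1cn(CCCCOc2cc(=O)oc3ccccc23)nn1`, gives 31% in this assay
- compound 2, `COc1ccccc1/C=C/C(=O)/C=C/c1ccc(OCc2cn(CCCCOc3cc(=O)oc4ccccc34)nn2)c(OC)c1`, gives 47% in this assay
- compound 3, `COc1ccc(/C=C/C(=O)/C=C/c2ccc(OCc3cn(CCCOc4cc(=O)oc5ccccc45)nn3)c(OC)c2)cc1OC`, gives 65% in this assay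

Compound 3 stands highest of the three numbers in this assay, with compound 2 nearest and compound 1 furthest, both steps to it beyond the scatter. The difference between the core of compound 2 and the core of compound 3 is not broken down here.

One change recurs twice in the set. From compound 2 to compound 1 it is hydrogen in place of methoxy on an aromatic carbon, and it made a step of a number 16 percentage points lower from compound 2 to compound 1 (beyond the scatter). Compound 4, `COc1ccc(/C=C/C(=O)/C=C/c2ccc(OCc3cn(CCCOc4cc(=O)oc5ccccc45)nn3)c(OC)c2)cc1`, is not yet measured; it arises from compound 3 by hydrogen in place of methoxy on an aromatic carbon. The two changes are of the same kind, but their surroundings differ: in compound 2 the leaving methoxy sits ortho to a large group, whereas in compound 3 it sits ortho to a methoxy group and meta to a large group.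

Among the compounds with values here, since the one measured instance of this kind of change lowered the number in this assay, a drop of similar size is expected from compound 3 to compound 4, namely a number 15 percentage points lower from compound 3 to compound 4 (beyond the scatter); this rests on the step of a number 16 percentage points lower from compound 2 to compound 1 (beyond the scatter) and on compound 3 giving 65%. The different surroundings leave room for a smaller or larger step, so the range is kept wide. Compound 4 is therefore estimated at 50%, between 36% and 64%, in this assay.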

Compound 4, percent growth inhibition at one concentration: 53%
Compound 4: middle estimate off by 3 percentage points, on the low side, within the range that was stated.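

In this assay, hydrogen in place of methoxy on an aromatic carbon, here 3,4-dimethoxyphenyl to 4-methoxyphenyl with the place ortho to a methoxy group and meta to a large group, gives a number 12 percentage points lower from compound 3 to compound 4 (beyond the scatter). Set beside the earlier instance on the other core, the change carries over in direction and in size, so within these two pairs the core makes no visible difference to the step: the same change on two cores in this assay, a number 16 percentage points lower (beyond the scatter) from compound 2 to compound 1 and a number 12 percentage points lower (beyond the scatter) from compound 3 to compound 4, 4 percentage points apart, within the scatter of two such steps. This rests on two pairs and a single tested concentration, so it shows agreement on these two cores only; it gives no general rule for the series and no explanation of why the number falls when the methoxy group leaves.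

The compounds shown leave open whether another group in the same place, such as a hydroxyl, a fluorine or an amine, would shift the number in the same way as methoxy does, and whether the step holds on a core carrying a carboxylic acid or a different aromatic ring substitution. From the compounds shown here alone, the part played by the linking chain alone also stays open, as does the effect of a longer chain on the size of this step.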